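Isobutyl for cyclohexyl at the assay limit

The compounds below may be only part of what the source reports. "The series", "measured", "known", "first", "only" and "open" are said of these compounds alone.

In a functional assay on HCT-15 cells (Homo sapiens) for antiproliferative activity, read by sulforhodamine B assay (a higher number here means a weaker inhibitor of growth, a lower number a stronger inhibitor of growth), compound 1 `CCCCCCOc1cccc(O)c1C(=O)/C=C/c1ccc(O)cc1` gives > 30000 nM, which is a limit. Compound 2 `O=C(/C=C/c1ccc(O)cc1)c1c(O)cccc1OCC1CCCCC1` gives > 30000 nM, also a limit, so its standing is not a number. Compound 3 `CC(C)CCOc1cccc(O)c1C(=O)/C=C/c1ccc(O)cc1` differs from compound 2 by isobutyl in place of cyclohexyl on a saturated chain carbon bound to an oxygen on an aromatic ring. Within the data shown here, the one measured step that bears on this is a step that the two limits leave unreadable from compound 1 to compound 2, so it offers no size to carry over. No step beyond the scatter is expected in this assay because the limit of > 30000 nM in this assay, at which 2 of the 2 values shown sit, marks where compound 1 and compound 2 both sit. The expected step is a number no higher from compound 2 to compound 3 (the limit leaves the size open). For compound 3 the estimate is 30000 nM, with an expected range of 12000 nM to 60000 nM.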

Compound 3, concentration for 50% growth inhibition: 10600 nM
For compound 3 the middle estimate is 2.8-fold (0.45 log units) above the measured one; measured number outside the range, below it.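

In this assay, isobutyl in place of cyclohexyl gives an at least 2.8-fold lower number from compound 2 to compound 3 (0.45 log units; beyond the scatter), and isopropyl in place of butyl gives an at least 2.8-fold lower number from compound 1 to compound 3 (0.45 log units; beyond the scatter). Among these compounds, the step between the other two compounds cannot be read, so these two steps are the first readable change at this place on the shared core. Compound 3 alone stands off the limit: the limit of > 30000 nM in this assay, at which 2 of the 3 values shown sit.

From the compounds shown here alone, the full size of both steps stays open. So does whether a shorter chain such as ethyl, or an amine at the chain end, would lower the number further.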